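The source may report more compounds than this note shows. Statements on the series, on what has been measured and on what is new or still open speak of the compounds shown alone.

Compound 1 `O=C1OCC[C@@H]1NC(=S)SCCOc1ccc([N+](=O)[O-])cc1`: > 64000 nM
Compound 2 `O=C(CNc1ccccc1F)N[C@H]1CCOC1=O`: > 64000 nM

Both measured compounds were examined in a functional assay on MCF7 cells (Homo sapiens) for antiproliferative activity, read by MTT assay, with a stated time of 72 h (a higher number here means a weaker inhibitor, a lower number a stronger inhibitor), and neither gave a number. Compound 1 reads > 64000 nM as a limit of the assay. Compound 2 reads > 64000 nM and this too is a limit. Compound 1 therefore stands at the limit of > 64000 nM in this assay, at which 2 of the 2 values shown sit, and has no measured potency to compare against.

The next compound is compound 3 `CC(=O)c1ccc(OCCSC(=S)N[C@H]2CCOC2=O)cc1`, which keeps the core of compound 1 and alters one group. Acetyl takes the place of nitro on an aromatic carbon, para to a large group acetyl in place of nitro on an aromatic carbon and the rest of the structure stays the same. Going by the values given here, no measured pair shows what a change of this kind does in this assay here. The expectation rests only on compound 1 with its limit of > 64000 nM and so no gain in potency is anticipated. The expected change is a number no higher from compound 1 to compound 3 (the limit leaves the size open) and it is estimated to lie within the scatter, in neither direction. The assay may well report only a limit again. The estimated value for compound 3 is 64000 nM with an expected range from 30000 nM to 128000 nM for its measurement.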

Compound 3, half-maximal inhibitory concentration: > 64000 nM
Compound 3: only a limit was reported; the forecaster's own chance of this, stated with the estimate: 80%; the middle value lies on the limit itself.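

The limits for compound 1 and compound 3 leave the exchange of nitro for acetyl unreadable, so no step can be read between these two compounds. All the values shown stand at one limit: the limit of > 64000 nM in this assay, at which 3 of the 3 values shown sit. The compounds shown leave open whether any change to the shared core would give a measured potency in this assay.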